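The source may report more compounds than this note shows. Statements on the series, on what has been measured and on what is new or still open speak of the compounds shown alone.

Measured compounds:
compound 1 `COc1ccc(-c2cc3ccccc3nc2C=O)cc1` — > 10000 nM
compound 2 `COc1ccc(-c2cc3ccccc3nc2/C=C/C(=O)c2c(OC)cccc2OC)cc1` — 7410 nM

In a functional assay on A549 cells (Homo sapiens) for antiproliferative activity, read by XTT assay, with a stated time of 72 h (on this read-out higher numbers stand for weaker inhibition and lower numbers for stronger inhibition), compound 1 reaches only a limit, > 10000 nM, and gives no number; this is the limit of > 10000 nM in this assay, at which 1 of the 2 values shown sits. Compound 2 stands as the only compound with a number shown in this assay, at 7410 nM. Compound 3 `COc1ccc(-c2cc3ccccc3nc2/C=C/C(=O)c2sccc2N)cc1` has not been measured yet. It differs from compound 2 in one place: 3-aminothiophen-2-yl in place of 2,6-dimethoxyphenyl on a carbonyl carbon. Among the compounds with values here, no measured pair of compounds in this set differs in one place, so no measured step tells how much such a change shifts the half-maximal inhibitory concentration. A modest step is expected from compound 2 to compound 3, in this assay, estimated as a 1.6-fold lower number from compound 2 to compound 3 (0.22 log units; within the scatter), towards stronger inhibition but close to the usual scatter. Compound 3 is therefore expected to give about 4500 nM in this assay, with a range from 1200 nM to 15000 nM.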

Compound 3, half-maximal inhibitory concentration: > 10000 nM
Compound 3 gave a limit, no number; the forecaster's own chance of this, stated with the estimate: 25%; at least 2.2-fold (0.34 log units) between middle value and limit.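

Placed on the carbonyl carbon, 3-aminothiophen-2-yl in place of 2,6-dimethoxyphenyl gives, in this assay, an at least 1.3-fold higher number from compound 2 to compound 3 (0.13 log units; that floor lies within the scatter). Within the data shown here, this is the first reading of any change at this place, and it shows that this replacement brings no stronger inhibition than the 2,6-dimethoxyphenyl group of compound 2. The true size of the step stays unknown, and the shift cannot be told from the scatter, because compound 3 reaches only a limit and not a number: the limit of > 10000 nM in this assay, at which 2 of the 3 values shown sit.

The compounds shown leave open whether any group on this carbonyl carbon can give clearly stronger inhibition than compound 2. A thiophen-2-yl group without the amine, or a plain phenyl group, would help separate the part played by the five-membered ring from that of the amine.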